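This account rests on a few compounds, and the source may have more. Where it says the series, first, only, none or still open, it means among the compounds named here.

Compound 1, `Cc1ccc(/C=C2\CN(C(=S)SCc3cn(Cc4cccc(Cl)c4)nn3)C/C(=C\c3ccc(C)cc3)C2=O)cc1`, opens the series. In a functional assay on PC-3 cells (Homo sapiens) for cytotoxicity, read by MTT assay, with a stated time of 24 h (a lower number here means a stronger inhibitor, a higher number a weaker inhibitor), compound 1 gives only a limit, > 80000 nM. Compound 2, `Cc1ccc(/C=C2\CN(C(=S)SCc3cn(Cc4ccccc4F)nn3)C/C(=C\c3ccc(C)cc3)C2=O)cc1`, differs from compound 1 by 2-fluorophenyl in place of 3-chlorophenyl on a saturated chain carbon bound to an aromatic nitrogen. In this assay compound 2 likewise gives only a limit, > 80000 nM. The step that the two limits leave unreadable from compound 1 to compound 2 cannot be sized because both values sit at the limit of > 80000 nM in this assay, at which 2 of the 3 values shown sit. Compound 3, `Cc1ccc(/C=C2\CN(Cc3cn(Cc4cccc(Cl)c4)nn3)C/C(=C\c3ccc(C)cc3)C2=O)cc1`, has a different core from compound 1; the difference between the two cores is not broken down here. In this assay, among the measured compounds shown here, compound 3 gives 29300 nM, the only number among the three measured compounds. Compound 4, `Cc1ccc(/C=C2\CN(Cc3cn(Cc4ccccc4F)nn3)C/C(=C\c3ccc(C)cc3)C2=O)cc1`, differs from compound 3 by 2-fluorophenyl in place of 3-chlorophenyl on a saturated chain carbon bound to an aromatic nitrogen, the same change that separates compound 1 from compound 2. Since that earlier step could not be read, the expected step of a 1.4-fold higher number from compound 3 to compound 4 (0.14 log units; within the scatter) rests mainly on compound 3 giving 29300 nM and on the swap being a halogen exchange between two similarly sized benzyl groups, so little movement is estimated. Compound 4 is therefore expected to give about 40000 nM in this assay, with an estimated range from 15000 nM to 100000 nM.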

Compound 4, half-maximal inhibitory concentration: 8800 nM
Compound 4: middle estimate off by 4.5-fold (0.66 log units), on the high side, and the stated range ends above it.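

In this assay, replacing 3-chlorobenzyl with 2-fluorobenzyl on the core of compound 3 gives a 3.3-fold lower number from compound 3 to compound 4 (0.52 log units; beyond the scatter), a modest step that lies beyond the scatter. The same replacement on the core of compound 1 cannot be read, because compound 1 and compound 2 each give only a limit of the assay and not a number: the limit of > 80000 nM in this assay, at which 2 of the 4 values shown sit. The series therefore shows the change lowering the number on one core only, and it shows neither that the step carries over to the other core nor that it fails to.

The change also swaps the halogen and its ring position together, so the compounds shown leave open which of the two matters. They also leave open how a plain benzyl group with no halogen, or a longer chain ending in an amine, would read at the same place on either core.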